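Hydrogen for isobutyl on an amide-type nitrogen

This account rests on a few compounds, and the source may have more. Where it says the series, first, only, none or still open, it means among the compounds named here.

In a functional assay on B16 cells (Mus musculus) for inhibition (a higher number here means a weaker inhibitor, a lower number a stronger inhibitor), compound 1 `CC(C)CN(CC(=O)N(CC(C)C)NC(=O)OCc1ccccc1)NC(=O)CBr` gives 1300 nM and compound 2 `CC(C)CN(NC(=O)OCc1ccccc1)C(=O)CN(Cc1ccccc1)NC(=O)CBr` gives 1400 nM. For the measured compounds named here, these two values lie within the scatter of each other, so compound 2 stands level with the only other measured compound.

Compound 3 `O=C(CN(Cc1ccccc1)NC(=O)CBr)NNC(=O)OCc1ccccc1` follows from compound 2 by one change: hydrogen in place of isobutyl on an amide-type nitrogen. This puts hydrogen in place of isobutyl on an amide-type nitrogen.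

Going by the values given here, only one measured step exists, a 1.1-fold higher number from compound 1 to compound 2 (0.03 log units; within the scatter). It put phenyl in place of isopropyl on a saturated chain carbon bound to an amine nitrogen, so it bears only indirectly. Among the compounds with values here, no measured compound shows a change on the amide-type nitrogen, and the direction stays open. In this assay, no shift beyond the scatter is expected.

The expected step is a 1.1-fold higher number from compound 2 to compound 3 (0.03 log units; within the scatter). The estimate for compound 3 is 1500 nM, with an expected range of 500 nM to 4500 nM.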

Compound 3, half-maximal inhibitory concentration: 700 nM
Estimate against measurement, compound 3: 2.1-fold (0.33 log units) above, and the stated range covers the measured number.
By their numbers in this assay, from the lowest: compounds 3, 1 and 2 (each within the scatter of the next).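

Working notes on the amide-type nitrogen: in this assay hydrogen in place of isobutyl gives a 2.0-fold lower number from compound 2 to compound 3 (0.30 log units; within the scatter) and is the first measured change at this position. The step does not separate compound 3 from compound 2, so inhibition in this assay persists with the four carbons of the isobutyl gone and the nitrogen left with only a hydrogen. Isobutyl is therefore not required here for a value in the range of compound 2, and nothing available explains the size of the step.

With only hydrogen and isobutyl to compare, the compounds shown do not say how this nitrogen responds to other groups. A methyl, a benzyl, a longer chain or a chain ending in a carboxylic acid or an amine could each test whether the position stays this tolerant.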